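Same Chlorophenyl Swap, Tried on a Second Core

The source may report more compounds than this note shows. Statements on the series, on what has been measured and on what is new or still open speak of the compounds shown alone.

Measured so far:
compound 1, `O=C(NNC(=O)c1ccccc1Cl)c1cccc(NS(=O)(=O)c2cnc(O)nc2O)c1`: 6070 nM
compound 2, `O=C(NNC(=O)c1cccc(NS(=O)(=O)c2cnc(O)nc2O)c1)c1cccc(Cl)c1`: 7310 nM
compound 3, `O=C(NNC(=O)c1ccccc1NS(=O)(=O)c1cnc(O)nc1O)c1ccccc1Cl`: 2410 nM

All three numbers come from a functional assay on SGC-7901 cells (Homo sapiens) for antiproliferative activity, read by MTT assay, with a stated time of 24 h; a higher number here means a weaker inhibitor, a lower number a stronger inhibitor. Compound 1 and compound 2 share one core; compound 3 is built from the same atoms joined differently, and the difference between the two cores is not broken down here. Within the first core, the change 3-chlorophenyl in place of 2-chlorophenyl on a carbonyl carbon produced a 1.2-fold higher number from compound 1 to compound 2 (0.08 log units; within the scatter), so compound 1 and compound 2 cannot be ordered against each other. Compound 3 shows the lowest number of the three, and its gaps to compound 1 and to compound 2 are both beyond the scatter, so it is the strongest inhibitor among the measured compounds.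

Compound 4, `O=C(NNC(=O)c1ccccc1NS(=O)(=O)c1cnc(O)nc1O)c1cccc(Cl)c1`, has not yet been measured in this assay. It differs from compound 3 by 3-chlorophenyl in place of 2-chlorophenyl on a carbonyl carbon, the same change as that between compound 1 and compound 2, at the same place on the carbonyl carbon. Since that earlier change gave only a 1.2-fold higher number from compound 1 to compound 2 (0.08 log units; within the scatter), a small step is expected here as well: the step from compound 3 to compound 4 is estimated as a 1.2-fold higher number from compound 3 to compound 4 (0.08 log units; within the scatter). Among the compounds with values here, compound 4 is therefore expected to give about 2900 nM in this assay, with the expected range running from 1500 nM to 6000 nM, because compound 3 gave 2410 nM and the single prior instance of this change moved the number little.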

Compound 4, half-maximal inhibitory concentration: 1820 nM
Beside the measured number, compound 4's estimate is 1.6-fold (0.20 log units) above it; the range from low to high includes it.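

In this assay, putting 3-chlorophenyl in place of 2-chlorophenyl on a carbonyl carbon gave a 1.3-fold lower number from compound 3 to compound 4 (0.12 log units; within the scatter) and so leaves compound 3 and compound 4 without an order between them. Carried over from the core of compound 1 to the core of compound 3, the change therefore behaves alike on both, with no readable effect on either, and the two steps do not differ: the same change on two cores in this assay, a 1.2-fold higher number (0.08 log units; within the scatter) from compound 1 to compound 2 and a 1.3-fold lower number (0.12 log units; within the scatter) from compound 3 to compound 4, 1.6-fold (0.20 log units) apart, within the scatter of two such steps. Within the data shown here, this shows only that the swap between these two chlorophenyl groups made no readable difference on two cores, with one pair on each; it does not show that the change has a fixed size or direction, and steps this small cannot show whether a larger effect would carry from one core to the other.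

The compounds shown leave open how a bromophenyl, a methoxyphenyl or a longer alkyl chain would fare on that same carbonyl carbon, and whether any such group would move the number beyond the scatter on either core. They also leave open whether the swap stays this small on any further core, or in any cells other than those used here.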